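The source may report more compounds than this note shows. Statements on the series, on what has been measured and on what is new or still open speak of the compounds shown alone.

Compound 1 `Cc1ccc(CS(=O)(=O)/C(=C/c2cccc(Cl)c2Cl)C(=O)c2ccc(Cl)cc2)cc1`: 1000 nM
Compound 2 `Cc1ccc(CS(=O)(=O)/C(=C/c2ccc(N(C)C)cc2)C(=O)c2ccc(Cl)cc2)cc1`: 50000 nM

In a functional assay on DU-145 cells (Homo sapiens) for inhibition, read by trypan blue exclusion, with a stated time of 96 h (on this read-out higher numbers stand for weaker inhibition of growth and lower numbers for stronger inhibition of growth), compound 2 has the higher number of the two, at 50000 nM. Compound 3 `Cc1ccc(CS(=O)(=O)/C(=C/c2c[nH]c3ccc(Br)cc23)C(=O)c2ccc(Cl)cc2)cc1` changes one group of compound 2: 5-bromo-1H-indol-3-yl in place of 4-(dimethylamino)phenyl on a double-bonded chain carbon bound to a double-bonded chain carbon. Among the measured compounds shown here, one measured step bears on this place, the large 50-fold higher number from compound 1 to compound 2 (1.70 log units; beyond the scatter), where 4-(dimethylamino)phenyl came in. Compound 3 removes that group, but 5-bromo-1H-indol-3-yl has not been measured, so only a partial return towards compound 1 at 1000 nM is expected. The estimated change is a 20-fold lower number from compound 2 to compound 3 (1.30 log units; beyond the scatter), meaning stronger inhibition of growth. For compound 3 the expected value is 2500 nM, with an estimated range of 300 nM to 20000 nM.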

Compound 3, concentration for 50% growth inhibition: 10000 nM
Compound 3: middle estimate off by 4.0-fold (0.60 log units), on the low side; the measured number falls inside the stated range.
By their numbers in this assay, from the lowest: compound 1; then compound 3; then compound 2.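

At this position, a group with two aromatic rings wins back only part of what 4-(dimethylamino)phenyl gave up: 5-bromo-1H-indol-3-yl brings a 5.0-fold lower number from compound 2 to compound 3 (0.70 log units; beyond the scatter), yet it also leaves a 10-fold higher number from compound 1 to compound 3 (1.00 log units; beyond the scatter). Among these three groups, 2,3-dichlorophenyl therefore keeps the lowest number, with both gaps beyond the scatter. No measurement here explains this order. Going by these compounds, it remains open whether the bromine or the indole itself drives the gain. The plain 1H-indol-3-yl group, without bromine, would help separate the two.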